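The source may report more compounds than this note shows. Statements on the series, on what has been measured and on what is new or still open speak of the compounds shown alone.

Compound 3 `C[C@@H]1N[C@H](C(=O)N2CCC[C@H]2C#N)C[C@@H]1C(=O)N1CCCC1` gives 88% in an assay on the whole organism (plasma, strain Sprague-Dawley) for inhibition of Dipeptidyl peptidase 4 (Rattus norvegicus), with a stated time of 10 h, at a dose of 1 mg/kg by the oral route (on this read-out higher numbers stand for more inhibition at the one dose given (going by the name of the read-out) and lower numbers for less inhibition), level with compound 1 `C[C@@H]1N[C@H](C(=O)N2CCC[C@H]2C#N)C[C@@H]1C(=O)N1CCC1` at 88%; compound 2 `CCN(C)C(=O)[C@H]1C[C@@H](C(=O)N2CCC[C@H]2C#N)N[C@H]1C` gives 79%. The measured steps at this carbonyl carbon, a number 9 percentage points lower from compound 1 to compound 2 (within the scatter), no change at the digits printed from compound 1 to compound 3 (within the scatter) and a number 9 percentage points higher from compound 2 to compound 3 (within the scatter), all lie within the scatter. Compound 4 `C[C@@H]1N[C@H](C(=O)N2CCC[C@H]2C#N)C[C@@H]1C(=O)N1CCSCC1` differs from compound 3 in one place: thiomorpholin-4-yl in place of pyrrolidin-1-yl on a carbonyl carbon. Going by the values given here, no measured step brings a six-membered ring with two hetero atoms onto this carbonyl carbon; the three steps bear only indirectly, and each was small. A step within the scatter is expected in this assay, in no fixed direction. Compound 4 is expected to give 85%, within 70% to 95%. The expected step of a number 3 percentage points lower from compound 3 to compound 4 (within the scatter) stays within the usual scatter.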

Compound 4, a percentage reported as inhibition, in the whole organism at one dose (the size of the read-out at that dose, not a potency): 85%
The estimate for compound 4 equals the measured number at the digits printed; the measured number falls inside the stated range.
By their numbers in this assay, from the lowest: compounds 2, 4, 1 and 3 (each within the scatter of the next).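

Thiomorpholin-4-yl on this carbonyl carbon joins azetidin-1-yl, pyrrolidin-1-yl and ethyl(methyl)amino as a group that leaves this assay within the scatter, with a number 3 percentage points lower from compound 3 to compound 4 (within the scatter) and a number 3 percentage points lower from compound 1 to compound 4 (within the scatter) and a number 6 percentage points higher from compound 2 to compound 4 (within the scatter) at this one dose. A six-membered ring with a second hetero atom therefore separates from none of the three earlier groups on this read-out. Nothing at hand gives a cause for these small steps. Open, going by these compounds, is whether morpholin-4-yl, or a piperazin-1-yl group with its free ring amine, on this carbonyl carbon would also stay within the scatter. On these data alone, a carboxylic acid on the ring also remains open.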